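The source may hold more compounds than are shown below. What is called first, only, known or untested is meant among the compounds shown, and "the series" means these compounds.

Compound 1 `COc1ccc(-c2cncnc2-c2cc(OC)c(OC)c(OC)c2)cc1F` is one of three compounds sharing a core that carries a trimethoxyphenyl group. In a functional assay on SiHa cells (Homo sapiens) for antiproliferative activity, read by CCK-8 assay, with a stated time of 72 h (on this read-out higher numbers stand for weaker inhibition and lower numbers for stronger inhibition), compound 1 gives 3340 nM, the second highest of the three numbers. Compound 2 `CCOc1ccc(-c2cncnc2-c2cc(OC)c(OC)c(OC)c2)cc1F` gives 800 nM, and the step of a 4.2-fold lower number from compound 1 to compound 2 (0.62 log units; beyond the scatter) shows that a small change on the chain bound to an oxygen on an aromatic ring already moves the number beyond the scatter. Compound 3 `CNC(=O)c1ccc(-c2cncnc2-c2cc(OC)c(OC)c(OC)c2)cc1` gives 10900 nM, so exchanging the group on that side of the core for a methylamide leaves compound 3 weaker than compound 1.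

Compound 4 `COc1cc(-c2ncncc2-c2ccc3cc[nH]c3c2)cc(OC)c1OC` differs from compound 1 by 1H-indol-6-yl in place of 3-fluoro-4-methoxyphenyl on an aromatic carbon on an aromatic carbon of the core. Within the data shown here, no measured step covers this exchange; the step from compound 1 to compound 2 and the gap between compound 1 and compound 3 only show that this side of the core is sensitive in both directions. Among the measured compounds shown here, with no direct precedent, a modest step of a 2.2-fold lower number from compound 1 to compound 4 (0.35 log units; beyond the scatter) is estimated, with wide uncertainty, and compound 4 is expected to give about 1500 nM, in a range from 200 nM to 10000 nM.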

Compound 4, half-maximal inhibitory concentration: 2180 nM
For compound 4 the middle estimate is 1.5-fold (0.16 log units) below the measured one; the range from low to high includes it.
By their numbers in this assay, from the lowest: compound 2; then compounds 4 and 1 (each within the scatter of the next); then compound 3.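

In this assay the exchange of 3-fluoro-4-methoxyphenyl for 1H-indol-6-yl on an aromatic carbon of the core gives a 1.5-fold lower number from compound 1 to compound 4 (0.19 log units; within the scatter) and the two compounds cannot be told apart. The position therefore takes a group with a five-membered aromatic ring and a hydrogen-bond donor, with no hydrogen-bond acceptor, and the number stays close to that of the substituted phenyl group it replaces. No measurement here explains why these two different groups give such similar numbers.

The compounds shown leave open whether a propoxy chain would go further than the step of a 4.2-fold lower number from compound 1 to compound 2 (0.62 log units; beyond the scatter) that the ethoxy group of compound 2 brought. They also leave open how a carboxylic acid or an amine on the aromatic ring at this position would behave.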